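Adding a second ester to an inactive compound

The compounds below may be only part of what the source reports. "The series", "measured", "known", "first", "only" and "open" are said of these compounds alone.

Compound 1 `CCCCCC(=O)Oc1cc(C(=O)C2=C3OC(C)(C)[C@@H](CC=C(C)C)C[C@@]34C[C@@H](CC=C(C)C)C(C)(C)[C@H]3CCC(C)(C)O[C@]34OC2=O)ccc1O`: > 20000 nM
Compound 2 `CCC(=O)Oc1cc(C(=O)C2=C3OC(C)(C)[C@@H](CC=C(C)C)C[C@@]34C[C@@H](CC=C(C)C)C(C)(C)[C@H]3CCC(C)(C)O[C@]34OC2=O)ccc1O`: > 20000 nM

In a functional assay on HeLa cells (Homo sapiens) for antiproliferative activity, read by MTT assay, with a stated time of 72 h (a lower number here means a stronger inhibitor, a higher number a weaker inhibitor), compound 1 gives > 20000 nM, which is a limit and not a number. Compound 2 gives > 20000 nM, which is also a limit. Together they make up (the limit of > 20000 nM in this assay, at which 2 of the 2 values shown sit).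

Compound 3 `CCCCCC(=O)Oc1ccc(C(=O)C2=C3OC(C)(C)[C@@H](CC=C(C)C)C[C@@]34C[C@@H](CC=C(C)C)C(C)(C)[C@H]3CCC(C)(C)O[C@]34OC2=O)cc1OC(=O)CCCCC` differs from compound 1 by pentylcarbonyl in place of hydrogen on an oxygen on an aromatic ring. This is pentylcarbonyl in place of hydrogen on an oxygen on an aromatic ring, so hydroxy becomes (pentylcarbonyl)oxy.

Among the compounds with values here, the only measured step is a step that the two limits leave unreadable from compound 1 to compound 2, and it concerns a different chain. It gives no size to carry over, so no step beyond the scatter is expected in this assay, and no direction can be named.

The expected change is a number no higher from compound 1 to compound 3 (the limit leaves the size open). Compound 3 is estimated at 20000 nM. The expected range for compound 3 runs from 8000 nM to 40000 nM, and another limit is likely.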

Compound 3, half-maximal inhibitory concentration: 15400 nM
For compound 3 the middle estimate is 1.3-fold (0.11 log units) above the measured one; measured number inside the range.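

Within the data shown here, replacing the hydroxy with (pentylcarbonyl)oxy, on an oxygen on an aromatic ring, gives the first actual number in this assay, and the step is an at least 1.2-fold lower number from compound 1 to compound 3 (0.11 log units; that floor lies within the scatter). So this oxygen can carry a second ester, with its free hydroxy gone, and the compound still gives a readable value, though a weak one on this scale. Since compound 1 is only a limit, the step has a floor but no fixed size, and the step from compound 1 to compound 2 cannot be read at all.

As far as these compounds go, it stays open whether the real gap from compound 1 to compound 3 lies beyond the scatter. The compounds shown also leave open what a shorter acetyl group, a longer chain or an amine-bearing ester would do on this same oxygen.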